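A few compounds are considered here, and "the series" means these few. Any claim that something is new, unique, unknown or untested is made for them only; others in the source may bear on it.

In a functional assay on NCI-H460 cells (Homo sapiens) for inhibition, read by CCK-8 assay, with a stated time of 72 h, tested at 10 uM (a higher number here means more inhibition of growth at the concentration tested, a lower number less inhibition of growth), compound 2 `CN(C)C(=O)c1cc2cnc(Nc3ccc(NC(=O)C4(C(=O)Nc5ccc(Cl)c(C(F)(F)F)c5)CC4)cc3)nc2n1C1CCCC1` gives 91.9%, within the scatter of compound 1 `CN(C)C(=O)c1cc2cnc(Nc3ccc(NC(=O)C4(C(=O)Nc5ccc(Br)cc5)CC4)cc3)nc2n1C1CCCC1` at 96.4%. Compound 3 `CN(C)C(=O)c1cc2cnc(Nc3ccc(NC(=O)C4(C(=O)Nc5ccc(O)cc5)CC4)cc3)nc2n1C1CCCC1` differs from compound 2 on an amide-type nitrogen: 4-hydroxyphenyl in place of 4-chloro-3-(trifluoromethyl)phenyl on an amide-type nitrogen. For the measured compounds named here, only one measured step bears on this, a number 4.5 percentage points lower from compound 1 to compound 2 (within the scatter). Going by the values given here, that step exchanges 4-bromophenyl for 4-chloro-3-(trifluoromethyl)phenyl, and no measured compound carries 4-hydroxyphenyl, so it offers only weak guidance. A modest loss of inhibition is tentatively expected, with the estimated step being a number 13.9 percentage points lower from compound 2 to compound 3 (beyond the scatter). For compound 3, the estimated value is 78%, with an expected range from 50% to 97%.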

Compound 3, percent growth inhibition at one concentration: 104%
For compound 3 the middle estimate is 26 percentage points below the measured one; the measured number lies above the stated range.
By their numbers in this assay, from the lowest: compounds 2, 1 and 3 (each within the scatter of the next, the first and the last beyond it).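

In this assay, for the compounds shown here, the aryl group on the amide-type nitrogen need not carry halogen: 4-hydroxyphenyl in place of 4-chloro-3-(trifluoromethyl)phenyl gives a number 12.1 percentage points higher from compound 2 to compound 3 (beyond the scatter), the first step beyond the scatter. Hydroxy in place of bromo on an aromatic carbon gives a number 7.6 percentage points higher from compound 1 to compound 3 (within the scatter), so a hydrogen-bond donor and acceptor here leaves inhibition indistinguishable from that of the bromo compound. Nothing available explains this result. From the compounds shown here alone, whether a methoxy group, an amine or a carboxylic acid in place of the hydroxy would hold this inhibition remains open.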